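This account rests on a few compounds, and the source may have more. Where it says the series, first, only, none or still open, it means among the compounds named here.

Working notes on the series, assayed in a functional assay on SW-620 cells (Homo sapiens) for cytotoxicity, read by MTT assay, with a stated time of 72 h; a lower number here means a stronger inhibitor, a higher number a weaker inhibitor. Compound 1 `Cc1ccc(-c2cc(/N=C3/NC(=O)CS3)cs2)cc1` gives only a limit, > 50000 nM, which is the limit of > 50000 nM in this assay, at which 1 of the 2 values shown sits. For the measured compounds named here, compound 2 `COc1ccc(/C=C2\S/C(=N\c3csc(-c4ccc(Cl)cc4)c3)NC2=O)cc1` gives 28100 nM in this assay, the only number so far among the two values shown. Compound 3 `CN(C)c1ccc(/C=C2\S/C(=N\c3csc(-c4ccc(Cl)cc4)c3)NC2=O)cc1` carries dimethylamino in place of methoxy on an aromatic carbon. Going by the values given here, no measured pair shows this change, so the step expected in this assay is a 1.9-fold lower number from compound 2 to compound 3 (0.27 log units; within the scatter), small and toward stronger inhibition, not clearly beyond the scatter. Compound 3 is expected to give 15000 nM in this assay, within 5000 nM to 45000 nM.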

Compound 3, half-maximal inhibitory concentration: 800 nM
Compound 3: middle estimate off by 19-fold (1.27 log units), on the high side, and the stated range ends above it.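

In this assay, the position on an aromatic carbon of a six-membered aromatic ring of carbon only, para to a large group, proves highly sensitive: dimethylamino in place of methoxy gives a 35-fold lower number from compound 2 to compound 3 (1.55 log units; beyond the scatter) in a single exchange. For the compounds shown here, this is the first sign that this position can move the read-out, and it rests on one pair. Nothing shown accounts for the size of this step.

Going by these compounds, whether the effect extends to another amine, such as pyrrolidine or morpholine, or to a plain ethyl group at the same carbon remains open.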